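A few compounds are considered here, and "the series" means these few. Any claim that something is new, unique, unknown or untested is made for them only; others in the source may bear on it.

Compound 1 `Cn1c(=O)c(=O)n(C2CCCC2)c2nc(N/N=C/c3ccc(O)cc3)ncc21`: > 100000 nM
Compound 2 `Cn1c(=O)c(=O)n(C2CCCC2)c2nc(N/N=C/c3ccc(Cl)cc3)ncc21`: 8420 nM

In a functional assay on PC-3 cells (Homo sapiens) for antiproliferative activity, read by MTT assay (on this read-out higher numbers stand for weaker inhibition and lower numbers for stronger inhibition), compound 1 gives only a limit, > 100000 nM. In this assay, among the measured compounds shown here, compound 2 gives 8420 nM, the only plain number among the two compounds measured. For the measured compounds named here, the single measured step, an at least 11-fold lower number from compound 1 to compound 2 (1.07 log units; beyond the scatter), changes a group on the same aromatic ring. Compound 3 `Cn1c(=O)c(=O)n(C2CCCC2)c2nc(N/N=C/c3ccc(F)c(Cl)c3)ncc21` carries 3-chloro-4-fluorophenyl in place of 4-chlorophenyl on a carbon with a double bond to nitrogen. Going by the values given here, no measured step adds a fluorine or shifts a chlorine, so this change has no direct precedent; the chlorine stays, and the expected step is one within the scatter, a 1.4-fold lower number from compound 2 to compound 3 (0.15 log units; within the scatter). Compound 3 is therefore estimated at 6000 nM, with a range from 2000 nM to 25000 nM.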

Compound 3, half-maximal inhibitory concentration: 8550 nM
The estimate for compound 3 lay 1.4-fold (0.15 log units) below the measured number; the measured number falls inside the stated range.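

In this assay, the change to 3-chloro-4-fluorophenyl gives a 1.0-fold higher number from compound 2 to compound 3 (0.01 log units; within the scatter), so the added fluorine and the new chlorine placement leave the read-out indistinguishable from that of 4-chlorophenyl. The comparison with the hydroxy compound gives an at least 11-fold lower number from compound 1 to compound 3 (1.06 log units; beyond the scatter), so a second chlorine-bearing ring also stands clear of 4-hydroxyphenyl. The true size of that step stays unknown, as compound 1 gives only a limit: the limit of > 100000 nM in this assay, at which 1 of the 3 values shown sits.

The compounds shown leave open whether chlorine is needed at all, since both rings with plain numbers carry it. They also leave open how a ring bearing an amine or a carboxylic acid would read here.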